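A few compounds are considered here, and "the series" means these few. Any claim that something is new, unique, unknown or untested is made for them only; others in the source may bear on it.

Measured compounds in an assay on Huh-7 cells for agonist activity at Bile acid receptor (Homo sapiens), read by a luciferase reporter; on this read-out lower numbers stand for an effect already at smaller amounts and higher numbers for an effect only at larger amounts of compound:
compound 1, `CC(C)c1onc(-c2c(Cl)cccc2Cl)c1COc1ccc(-c2nc3ccc(C(=O)O)cc3n2CC2CCCCC2)c(F)c1`: 7.8 nM
compound 2, `CC(C)c1onc(-c2c(Cl)cccc2Cl)c1COc1ccc(-c2nc3ccc(C(=O)O)cc3n2C2CC2)cc1`: 16.5 nM
compound 3, `CC(C)c1onc(-c2c(Cl)cccc2Cl)c1COc1ccc(-c2nc3ccc(C(=O)O)cc3n2-c2ccc(F)cc2)cc1`: 32.2 nM

Compound 3 gives the highest of the three numbers in this assay. Its nearest neighbour is compound 2, and the step of a 2.0-fold higher number from compound 2 to compound 3 (0.29 log units; within the scatter) lies within the scatter. Among the measured compounds shown here, compound 1 stands further off, its number below that of compound 3 by a gap beyond the scatter, but compound 1 differs from compound 3 in more than one place, so no single step is drawn from that pair.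

Compound 4, `CC(C)c1onc(-c2c(Cl)cccc2Cl)c1COc1ccc(-c2nc3ccc(C(=O)O)cc3n2C2CCC2)cc1`, has not yet been measured in this assay. It differs from compound 3 in one place: cyclobutyl in place of 4-fluorophenyl on an aromatic nitrogen. For the measured compounds named here, the one measured step that bears on this change is a 2.0-fold higher number from compound 2 to compound 3 (0.29 log units; within the scatter), where the cyclopropyl on the aromatic nitrogen was exchanged for the 4-fluorophenyl and the number stayed within the scatter. Compound 4 goes the other way, back from the 4-fluorophenyl to a cyclobutyl. Compound 4 is therefore expected to show a step of a 2.1-fold lower number from compound 3 to compound 4 (0.33 log units; beyond the scatter) that stays within the scatter, leaning towards a lower number. For compound 4 in this assay the estimate is 15 nM, with a range from 6 nM to 38 nM.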

Compound 4, half-maximal effective concentration: 14.4 nM
The estimate for compound 4 lay 1.0-fold (0.02 log units) above the measured number, within the range that was stated.
By their numbers in this assay, from the lowest: compounds 1, 4, 2 and 3 (each within the scatter of the next, the first and the last beyond it).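

In this assay, among the compounds shown here, cyclobutyl in place of 4-fluorophenyl on the aromatic nitrogen gives a 2.2-fold lower number from compound 3 to compound 4 (0.35 log units; beyond the scatter), the first step at this position that is printed beyond the scatter, while the earlier exchange, a 2.0-fold higher number from compound 2 to compound 3 (0.29 log units; within the scatter), stayed within it. Cyclobutyl in place of cyclopropyl gives a 1.1-fold lower number from compound 2 to compound 4 (0.06 log units; within the scatter), so these two non-aromatic carbon rings cannot be told apart at this position, and the 4-fluorophenyl is separated from cyclobutyl but not from cyclopropyl. Nothing measured for these compounds accounts for the modest gap between the 4-fluorophenyl and the cyclobutyl.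

From the compounds shown here alone, it remains open how a cyclohexyl ring set directly on the aromatic nitrogen, a straight alkyl chain or a chain ending in an amine would read here, and whether an unsubstituted phenyl would sit with the 4-fluorophenyl or with the two non-aromatic rings. Compound 1 differs from these compounds in more than one place, so it settles none of these questions for the group on the aromatic nitrogen.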